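Chlorophenyl Analogues and a 2-Bromophenyl Question

The source may report more compounds than this note shows. Statements on the series, on what has been measured and on what is new or still open speak of the compounds shown alone.

Measured in a functional assay on MCF7 cells (Homo sapiens) for cytotoxicity, read by MTT assay, with a stated time of 72 h; a higher number here means a weaker inhibitor, a lower number a stronger inhibitor:
- Compound 1 `COc1ccc(/C=C2\CCC/C(=C\c3ccccc3Cl)C2=O)cc1OC`: 10400 nM
- Compound 2 `COc1ccc(/C=C2\CCC/C(=C\c3cccc(Cl)c3)C2=O)cc1OC`: 6000 nM
- Compound 3 `COc1ccc(/C=C2\CCC/C(=C\c3ccc(Cl)cc3)C2=O)cc1OC`: 6300 nM

Compound 3 stands within the scatter of both other compounds: a 1.1-fold higher number from compound 2 to compound 3 (0.02 log units; within the scatter) and a 1.7-fold lower number from compound 1 to compound 3 (0.22 log units; within the scatter). Compound 4 `COc1ccc(/C=C2\CCC/C(=C\c3ccccc3Br)C2=O)cc1OC` carries 2-bromophenyl in place of 4-chlorophenyl on a double-bonded chain carbon bound to a double-bonded ring carbon. Among the measured compounds shown here, no bromine compound has been measured, so the closest guide is compound 1, the 2-chlorophenyl member, at 10400 nM. For the measured compounds named here, the steps that bear on the change are a 1.7-fold lower number from compound 1 to compound 2 (0.24 log units; within the scatter) and a 1.7-fold lower number from compound 1 to compound 3 (0.22 log units; within the scatter), both small. A small move to a higher number in this assay is therefore expected, not beyond the scatter. The expected step is a 1.4-fold higher number from compound 3 to compound 4 (0.15 log units; within the scatter). For compound 4 the estimated value is 9000 nM, with an expected range of 4500 nM to 18000 nM.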

Compound 4, half-maximal inhibitory concentration: 9500 nM
Compound 4: the middle estimate sits 1.1-fold (0.02 log units) below what was measured; low and high end bracket the measured number.
By their numbers in this assay, from the lowest: compounds 2, 3, 4 and 1 (each within the scatter of the next).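

In this assay, bromo in place of chloro on an aromatic carbon gives a 1.1-fold lower number from compound 1 to compound 4 (0.04 log units; within the scatter), so the 2-bromophenyl and 2-chlorophenyl members cannot be told apart. Against the other chlorophenyl members the steps are a 1.5-fold higher number from compound 3 to compound 4 (0.18 log units; within the scatter) and a 1.6-fold higher number from compound 2 to compound 4 (0.20 log units; within the scatter), which keeps all four compounds within the scatter of one another. Nothing available offers an explanation for this result. Still open, as far as these compounds go, is whether 3-bromophenyl or 4-bromophenyl would match their chlorine counterparts, and whether a phenyl carrying an amine or a carboxylic acid at this place would step beyond the scatter.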